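The compounds below may be only part of what the source reports. "The series", "measured", "known", "first", "only" and "open" are said of these compounds alone.

Measured so far in an ADME assay on HEK293 cells (Homo sapiens) for cytotoxicity, read by luminescence, with a stated time of 72 h; a lower number here means that less compound is needed, a higher number that more compound is needed for the effect:
- Compound 1 `CCOC(=O)c1c(-c2cccc(Oc3ccccc3)c2)[nH]c2cc(Cl)c(OC)cc2c1=O`: > 22000 nM, a limit
- Compound 2 `CCOC(=O)c1c(-c2cccc(-c3ccccc3)c2)[nH]c2cc(Cl)c(Cl)cc2c1=O`: > 22000 nM, a limit
- Compound 3 `CCOC(=O)c1c(-c2cccc(OC)c2)[nH]c2cc(Cl)c(Cl)cc2c1=O`: > 22000 nM, a limit

Compound 3 has no number in this assay and stands only at the limit of > 22000 nM. The series as a whole offers no number either, with the limit of > 22000 nM in this assay, at which 3 of the 3 values shown sit.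

The next compound is compound 4 `CCOC(=O)c1c(-c2cccc(Oc3ccccc3)c2)[nH]c2cc(Cl)c(Cl)cc2c1=O`. The change is phenyl in place of methyl on an oxygen on an aromatic ring, which is phenyl in place of methyl on an oxygen on an aromatic ring.

Among the compounds with values here, the one measured step that bears on it is a step that the two limits leave unreadable from compound 2 to compound 3, so it gives no size to carry over. Compound 1, which also carries a phenoxy group, reads > 22000 nM, again a limit.

No step beyond the scatter is therefore expected in this assay, in either direction, and another limit is the likeliest report. The expected step is a step that the limit leaves unreadable from compound 3 to compound 4.

For compound 4 the estimate is 25000 nM, with an expected range from 12000 nM to 50000 nM.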

Compound 4, half-maximal effective concentration: > 22000 nM
Compound 4 gave a limit, no number; the forecaster's own chance of this, stated with the estimate: 85%; the middle value does not contradict the limit.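

In this assay compound 4 gives > 22000 nM, which is a limit and not a number. Within the data shown here, no step from compound 1, compound 2 or compound 3 to compound 4 can be read. The compounds shown leave open what concentration any of them would need for the half-maximal effect, and whether their differences matter here: the limit of > 22000 nM in this assay, at which 4 of the 4 values shown sit.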